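Swapping the nitrogen substituent of compound 1

This account rests on a few compounds, and the source may have more. Where it says the series, first, only, none or still open, it means among the compounds named here.

- compound 1 `CC(=O)c1c(NCc2ccc(F)cc2)[nH]c2c(F)cc(F)cc2c1=O` gives > 25000 nM (a limit)
- compound 2 `COc1ccc(CNc2[nH]c3c(F)cc(F)cc3c(=O)c2C(C)=O)cc1` gives > 25000 nM (a limit)

In an ADME assay on Vero cells (Chlorocebus sabaeus) for cytotoxicity (on this read-out higher numbers stand for lower toxicity in this test and lower numbers for higher toxicity in this test), compound 1 has only a limit and no number (> 25000 nM). It stands at the limit of > 25000 nM in this assay, at which 2 of the 2 values shown sit, and no exact value is available. Compound 3 `COc1ccc(Nc2[nH]c3c(F)cc(F)cc3c(=O)c2C(C)=O)cc1` has 4-methoxyphenyl in place of 4-fluorobenzyl on a nitrogen on an aromatic ring. Among the measured compounds shown here, the only measured change that bears on this is methoxy in place of fluoro on an aromatic carbon, and it is a step that the two limits leave unreadable from compound 1 to compound 2 and so offers no size to carry over. No step beyond the scatter is therefore expected in this assay for this change, and another limit is likely. The expected step is a number no higher from compound 1 to compound 3 (the limit leaves the size open) in size. For compound 3 the estimated value is 25000 nM (expected range 10000 nM to 50000 nM).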

Compound 3, half-maximal cytotoxic concentration: > 25000 nM
Compound 3: a limit, no number; the forecaster's own chance of this, stated with the estimate: 75%; the middle value sits exactly at the limit.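

Compound 1 and compound 3 both give only a limit in this assay, so no step can be read between them: the limit of > 25000 nM in this assay, at which 3 of the 3 values shown sit.

The compounds shown leave open how far apart their true half-maximal cytotoxic concentrations lie, and whether any nitrogen substituent would bring a number within reach.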